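The source may report more compounds than this note shows. Statements on the series, on what has been measured and on what is new or still open speak of the compounds shown alone.

Within the data shown here, in a physicochemical assay for solubility, in phosphate buffer, at pH 7.4 (on this read-out lower numbers stand for lower solubility and higher numbers for higher solubility), compound 2 `CC(=O)N[C@@H]1CCC[C@H](C(=O)Nc2cc(-c3cnn4c3CC(C)(C)C4)ccn2)C1` gives 970000 nM, the only actual number so far. Compound 1 `CC(=O)N[C@@H]1CCC[C@H](C(=O)Nc2cc(-c3cnn4c3CCCC4)c(F)cn2)C1` reads > 1000000 nM, which is a limit of the assay and not a number. Compound 3 `CC(=O)N[C@@H]1CCC[C@H](C(=O)Nc2cc(-c3cnn4c3CC(C)(C)C4)c(F)cn2)C1` carries fluoro in place of hydrogen on an aromatic carbon of the six-membered aromatic ring with 1 nitrogen (fluoro in place of hydrogen on an aromatic carbon). Among the measured compounds shown here, no measured pair isolates this change, so no shift beyond the scatter is expected in this assay. The expected step is small, a 1.2-fold lower number from compound 2 to compound 3 (0.08 log units; within the scatter). Compound 3 is estimated at 800000 nM, with an expected range of 400000 nM to 1000000 nM.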

Compound 3, solubility: 550000 nM
For compound 3 the middle estimate is 1.5-fold (0.16 log units) above the measured one; the measured number falls inside the stated range.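

In this assay, fluoro in place of hydrogen on an aromatic carbon, ortho to a large group, now has a measured pair: a 1.8-fold lower number from compound 2 to compound 3 (0.25 log units; within the scatter). At this position the change therefore gives no shift beyond the scatter. The exchange of the group of 9 heavy atoms for the group of 10 heavy atoms gives an at least 1.8-fold lower number from compound 1 to compound 3 (0.25 log units; that floor lies within the scatter), and this is only a floor because compound 1 reads a limit and not a number: the limit of > 1000000 nM in this assay, at which 1 of the 3 values shown sits.

On these data alone, whether chloro, a methoxy group or an amine in place of the fluoro moves the reading beyond the scatter stays open. As far as these compounds go, the full size of the step between the two ring groups also stays open.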